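This account rests on a few compounds, and the source may have more. Where it says the series, first, only, none or still open, it means among the compounds named here.

Compound 1 `COC(=O)c1cccc(-c2ccc(OC)c(S(=O)(=O)Nc3cccc(NCCNC(=O)c4ccccc4OC)c3)c2)c1`: in an assay on CHO-K1 cells for agonist activity at Orexin receptor type 2 (Homo sapiens), read by a luciferase reporter (a lower number here means that less compound is needed, a higher number that more compound is needed for the effect), compound 1 shows only a limit, > 10000 nM.
Compound 2 `CNC(=O)c1cccc(-c2ccc(OC)c(S(=O)(=O)Nc3cccc(NCCNC(=O)c4ccccc4OC)c3)c2)c1`: in this assay compound 2 gives 182 nM.

Going by the values given here, compound 2 holds the only number in this assay; the other value shown is a limit. Among the compounds with values here, the one measured step, methylamino in place of methoxy on a carbonyl carbon, is an at least 54-fold lower number from compound 1 to compound 2 (1.73 log units; beyond the scatter), and its size is bounded by the limit of > 10000 nM in this assay, at which 1 of the 2 values shown sits.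

Compound 3 `COc1ccccc1C(=O)NCCNc1cccc(NS(=O)(=O)c2cc(-c3cccc(C(=O)N(C)C)c3)ccc2OC)c1` differs from compound 2 by methyl in place of hydrogen on an amide-type nitrogen. The measured step touches the same carbonyl but exchanges the group on it rather than adding a methyl to the amide-type nitrogen, so it bears on the new change only loosely. Within the data shown here, with no step that leaves a methylcarbamoyl intact and alters only its nitrogen, no direction can be drawn from the data; a modest step in this assay is expected for compound 3, a 1.9-fold higher number from compound 2 to compound 3 (0.28 log units; within the scatter). Compound 3 is estimated at 350 nM, within 100 nM to 1500 nM.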

Compound 3, half-maximal effective concentration: 50 nM
Compound 3: the middle estimate sits 7.0-fold (0.85 log units) above what was measured, and the stated range ends above it.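

On the carbonyl of the 3-(methylcarbamoyl)phenyl group, the amide hydrogen is not needed for the effect in this assay: methyl in its place gives a 3.6-fold lower number from compound 2 to compound 3 (0.56 log units; beyond the scatter), so the amide nitrogen itself is a position where a single added carbon moves the number beyond the scatter. Dimethylamino in place of methoxy on the same carbonyl carbon reads as an at least 200-fold lower number from compound 1 to compound 3 (2.30 log units; beyond the scatter), so this step and the earlier methylamino step run in the same direction. Compound 1 stands at a limit of the assay, not at a number, so the size of this step is bounded: the limit of > 10000 nM in this assay, at which 1 of the 3 values shown sits.

As far as these compounds go, whether the trend continues with larger groups on this nitrogen, such as ethyl or a ring amide like pyrrolidine, stays open. So does the effect of an unsubstituted carboxamide or a carboxylic acid on this carbonyl.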